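Extending the methyl of compound 1 with an amide group

The compounds below may be only part of what the source reports. "The series", "measured", "known", "first", "only" and "open" are said of these compounds alone.

Compound 1 `CCSC(=S)SCC(=O)c1ccc(C)cc1` stands at the weak end of the three measured compounds in an assay on HEK293 cells for inhibition of protein deacetylase HDAC6 (Homo sapiens) (on this read-out lower numbers stand for stronger inhibition and higher numbers for weaker inhibition), where compound 1 gives 1250 nM. Compound 3 `CCSC(=S)SCC(=O)c1ccc(C(=O)Nc2ccccc2)cc1`, which carries a larger amide-bearing substituent on the aromatic ring, gives 521 nM in this assay, a lower number beyond the scatter. Compound 2 `CCOC(=S)SCC(=O)c1ccc(NC(C)=O)cc1` differs from compound 1 at several places. In this assay compound 2 gives 90 nM, the lowest number of the three. Compound 4 `CCSC(=S)SCC(=O)c1ccc(CN(C)C(C)=O)cc1` has not yet been measured. It differs from compound 1 by acetyl(methyl)amino in place of hydrogen on a saturated chain carbon bound to an aromatic carbon, so that the methyl of compound 1 becomes an (acetyl(methyl)amino)methyl group. Both measured compounds that carry an amide-containing substituent on the ring, compound 2 with 90 nM and compound 3 with 521 nM, sit below compound 1. On that basis a moderate drop is expected for compound 4. Compound 4 is therefore estimated at 450 nM in this assay, within a range of 150 nM to 1300 nM. The expected step from compound 1 to compound 4 is a 2.8-fold lower number from compound 1 to compound 4 (0.44 log units; beyond the scatter), beyond the scatter but not large.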

Compound 4, half-maximal inhibitory concentration: 256 nM
For compound 4 the middle estimate is 1.8-fold (0.24 log units) above the measured one; low and high end bracket the measured number.
By their numbers in this assay, from the lowest: compound 2; then compound 4; then compound 3; then compound 1.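

In this assay, among the compounds shown here, the change from methyl to (acetyl(methyl)amino)methyl gives a 4.9-fold lower number from compound 1 to compound 4 (0.69 log units; beyond the scatter), the first step in this set that can be read at a single place. It shows that on this saturated chain carbon bound to an aromatic carbon, a group of 5 heavy atoms can replace hydrogen and the number still falls, modestly but beyond the scatter. No available evidence bears on the reason for this fall.

The compounds shown leave open whether the step goes with the acetyl part or the methyl on nitrogen, which a dimethylamino or an acetylamino group on the same carbon would help to separate. Also open, as far as these compounds go, is how a longer chain between the ring and the amide, or a carboxylic acid in its place, would read out.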